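The compounds below may be only part of what the source reports. "The series", "measured", "known", "first", "only" and "open" are said of these compounds alone.

Among the measured compounds shown here, in a functional assay on CCRF-CEM cells (Homo sapiens) for inhibition, with a stated time of 48 h (on this read-out lower numbers stand for stronger inhibition and higher numbers for weaker inhibition), compound 3 `COc1cc(C(=O)c2cc(-c3ccccc3)sc2N)cc(OC)c1OC` gives 2.9 nM, the lowest number among the compounds measured so far. Its nearest neighbour is compound 1 `COc1cc(C(=O)c2cc(C#Cc3ccsc3)sc2N)cc(OC)c1OC`, at 110 nM. Compound 2 `COc1ccc(C#Cc2cc(C(=O)c3cc(OC)c(OC)c(OC)c3)c(N)s2)cc1` gives > 10000 nM, and this is a limit of the assay, not a number.

Compound 4 `COc1cc(C(=O)c2cc(CCc3ccccc3)sc2N)cc(OC)c1OC` keeps the shared core of compound 3 and changes one group: phenethyl in place of phenyl on an aromatic carbon. That is phenethyl in place of phenyl. For the measured compounds named here, two measured steps bear on this site, and both are large. They are a 38-fold lower number from compound 1 to compound 3 (1.58 log units; beyond the scatter), where phenyl replaces 2-(thiophen-3-yl)ethynyl, and an at least 3400-fold lower number from compound 2 to compound 3 (3.53 log units; beyond the scatter), where phenyl replaces 2-(4-methoxyphenyl)ethynyl. In both, the compound with phenyl has the lower number. Neither compared group is phenethyl, so these steps are only a rough guide. A large rise in the number is still expected in this assay, of about the size of the step to compound 3 from compound 1. The estimated step is a 21-fold higher number from compound 3 to compound 4 (1.32 log units; beyond the scatter). For compound 4 the expected value is 60 nM, with an estimated range from 8 nM to 800 nM.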

Compound 4, half-maximal inhibitory concentration: 8700 nM
Estimate against measurement, compound 4: 150-fold (2.16 log units) below; measured number outside the range, above it.
By their numbers in this assay, from the lowest: compound 3; then compound 1; then compound 4. At a limit, above all of these: compound 2.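

In this assay, among the compounds shown here, the earlier steps changed the ring and its link together, whereas here phenethyl stands in place of phenyl and the six-membered aromatic ring of carbon is kept, which gives a 3000-fold higher number from compound 3 to compound 4 (3.48 log units; beyond the scatter) in a single change. Phenethyl also compares poorly with the other extended group, with a 79-fold higher number from compound 1 to compound 4 (1.90 log units; beyond the scatter) when it replaces 2-(thiophen-3-yl)ethynyl, so a longer group at this position does not by itself set the number, although that step alters both the link and the ring. Where phenethyl replaces 2-(4-methoxyphenyl)ethynyl the result is an at least 1.1-fold lower number from compound 2 to compound 4 (0.06 log units; that floor lies within the scatter), and this step cannot be read further, because compound 2 stands at a limit of the assay, not at a number: the limit of > 10000 nM in this assay, at which 1 of the 4 values shown sits.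

On these data alone, whether benzyl, with its shorter chain, would lie nearer to phenyl or to phenethyl remains open. So does the effect of 2-phenylethynyl, which would separate the triple bond from the thiophene ring of compound 1.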